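This account rests on a few compounds, and the source may have more. Where it says the series, first, only, none or still open, it means among the compounds named here.

Measured in a functional assay on HCT-116 cells (Homo sapiens) for cytotoxicity, read by MTT assay, with a stated time of 48 h; on this read-out higher numbers stand for weaker inhibition and lower numbers for stronger inhibition:
compound 1, `O=C(/C=C/c1ccc2c(c1)B(O)OC2)c1ccc(O)cc1`, gives 24100 nM
compound 2, `Nc1ccc(C(=O)/C=C/c2ccc3c(c2)B(O)OC3)cc1`, gives 26100 nM
compound 3, `O=C(/C=C/c1ccc2c(c1)B(O)OC2)c1cccc(O)c1`, gives 6500 nM

Compound 1 and compound 2 differ by amino in place of hydroxy on an aromatic carbon, and the step is a 1.1-fold higher number from compound 1 to compound 2 (0.03 log units; within the scatter). Compound 3 differs from compound 1 by 3-hydroxyphenyl in place of 4-hydroxyphenyl on a carbonyl carbon; the step is a 3.7-fold lower number from compound 1 to compound 3 (0.57 log units; beyond the scatter), and against compound 2 it is a 4.0-fold lower number from compound 2 to compound 3 (0.60 log units; beyond the scatter). Compound 3 has the lowest number of the three.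

Compound 4, `Nc1cccc(C(=O)/C=C/c2ccc3c(c2)B(O)OC3)c1`, is not yet measured. It differs from compound 3 by amino in place of hydroxy on an aromatic carbon. This is the same kind of change as from compound 1 to compound 2, though the place is not identical: there the group sat para to a large group, here meta to a large group. The step from compound 3 to compound 4 in this assay is expected to be a 1.1-fold higher number from compound 3 to compound 4 (0.03 log units; within the scatter), within the scatter, because the earlier step was a 1.1-fold higher number from compound 1 to compound 2 (0.03 log units; within the scatter). Compound 4 is estimated at 7000 nM, with a likely range from 3500 nM to 14000 nM.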

Compound 4, half-maximal inhibitory concentration: 4500 nM
Compound 4: the middle estimate sits 1.6-fold (0.19 log units) above what was measured; low and high end bracket the measured number.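

In this assay, amino in place of hydroxy carries from one core to the other with no step beyond the scatter: the same change on two cores in this assay, a 1.1-fold higher number (0.03 log units; within the scatter) from compound 1 to compound 2 and a 1.4-fold lower number (0.16 log units; within the scatter) from compound 3 to compound 4, 1.6-fold (0.19 log units) apart, within the scatter of two such steps. The new step is a 1.4-fold lower number from compound 3 to compound 4 (0.16 log units; within the scatter), whereas 3-aminophenyl set against the 4-substituted phenyl groups gives a 5.8-fold lower number from compound 2 to compound 4 (0.76 log units; beyond the scatter) and a 5.4-fold lower number from compound 1 to compound 4 (0.73 log units; beyond the scatter). Two pairs in one cell assay do not show that the swap would stay this small on any other core or in any other assay.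

Still open, on these data alone, is how a methoxy group, a fluorine atom or a carboxylic acid would read in place of the amino or hydroxy group. Also open, as far as these compounds go, is whether these numbers hold on a core without the boron atom.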